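Removing One Nitro Group: Cytotoxicity in H9 Cells

This account rests on a few compounds, and the source may have more. Where it says the series, first, only, none or still open, it means among the compounds named here.

This account concerns three measured compounds and one still to be measured, all tested in an ADME assay on H9 cells (Homo sapiens) for cytotoxicity, read by XTT assay, with a stated time of 6 days; on this read-out lower numbers stand for higher toxicity in this test and higher numbers for lower toxicity in this test. Going by the values given here, compound 1, `Cc1cccc(C)c1Oc1ccc([N+](=O)[O-])c(Nc2ccc(C#N)cc2)c1`, is the only one with a plain number: in this assay compound 1 gives 69600 nM. Compound 2, `Cc1cc(C#N)cc(C)c1Oc1ccc([N+](=O)[O-])c(Nc2ccc(C#N)cc2)c1`, carries cyano in place of hydrogen on an aromatic carbon, and in this assay compound 2 reaches only a limit, > 65100 nM. The step that the limit leaves unreadable from compound 1 to compound 2 therefore cannot be read, as the limit of > 65100 nM in this assay, at which 1 of the 3 values shown sits, shows. Compound 3, `Cc1cc(C)c(Oc2cc(Nc3ccc(C#N)cc3)c([N+](=O)[O-])cc2[N+](=O)[O-])c(C)c1`, likewise stands at a limit: in this assay compound 3 gives > 59800 nM, a limit rather than a number, as the limit of > 59800 nM in this assay, at which 1 of the 3 values shown sits, records. Compound 4, `Cc1cc(C)c(Oc2ccc([N+](=O)[O-])c(Nc3ccc(C#N)cc3)c2)c(C)c1`, differs from compound 3 in one place: hydrogen in place of nitro on an aromatic carbon. No measured step bears on this change directly, and the one step shown, from compound 1 to compound 2, is itself unreadable. Among the compounds with values here, every value so far sits at or close to the top of the measurable window, so no movement beyond the scatter is expected. Compound 4 is thus estimated at 65000 nM, between 30000 nM and 150000 nM, with a limit again a likely outcome. The step that the limit leaves unreadable from compound 3 to compound 4 is expected to stay within the scatter.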

Compound 4, half-maximal cytotoxic concentration: > 67000 nM
Compound 4: only a limit was reported; the forecaster's own chance of this, stated with the estimate: 60%; at least 1.0-fold (0.01 log units) between middle value and limit.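

In this assay compound 4 reaches only a limit, > 67000 nM. Its steps from compound 1, compound 2 and compound 3 therefore cannot be read: the limit of > 67000 nM in this assay, at which 1 of the 4 values shown sits. The compounds shown leave open how far any of these changes, including the loss of the nitro group, moves the half-maximal cytotoxic concentration.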